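The compounds below may be only part of what the source reports. "The series", "measured", "known", "first", "only" and "open" are said of these compounds alone.

The measured compounds:
compound 1, `COc1cccc(Cn2cc(-c3ccc(C)cc3)nn2)c1`, gives 19500 nM
compound 2, `CCOC(=O)Cn1cc(-c2ccc3ccccc3c2)nn1`, gives > 100000 nM
compound 3, `Cc1cccc(-c2cn(CC3COC(C)(C)O3)nn2)c1`, gives 41700 nM

All three were tested in a functional assay on B16 cells (Mus musculus) for cytotoxicity, read by MTT assay, with a stated time of 48 h; a lower number here means a stronger inhibitor, a higher number a weaker inhibitor. Compound 1 and compound 3 return numbers, and the gap between them is within the usual scatter, so neither can be called the stronger. For compound 2 the result is a limit, not a number. Compound 2 sits at the limit of > 100000 nM in this assay, at which 1 of the 3 values shown sits, and it is the only one of the three that does. Nothing finer about compound 2 is known from this assay.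

The step to compound 4, `OCCCn1cc(-c2ccc3ccccc3c2)nn1`, changes one place: 2-hydroxyethyl in place of ethoxycarbonyl on a saturated chain carbon bound to an aromatic nitrogen. Within the data shown here, no step between two measured compounds is available to guide the size of this change. Given that compound 1 gives 19500 nM and compound 3 gives 41700 nM, compound 4 is expected to stay in the weak range, with the step of an at least 1.4-fold lower number from compound 2 to compound 4 (0.15 log units; that floor lies within the scatter) amounting to little beyond the scatter. The result for compound 4 may again come back as a limit rather than a number. The estimate for compound 4 in this assay is 70000 nM, with a range from 20000 nM to 250000 nM.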

Compound 4, half-maximal inhibitory concentration: > 100000 nM
Compound 4: only a limit was reported; the forecaster's own chance of this, stated with the estimate: 45%; middle value at least 1.4-fold (0.15 log units) away from the limit.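

Compound 4 returns a limit, > 100000 nM, and not a number. Among these compounds, compound 2 also stands at a limit, so no step between compound 2 and compound 4 can be read. The compounds shown leave open whether 2-hydroxyethyl in place of ethoxycarbonyl changes the result at all in this assay.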